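Naphthalene to fluorophenyl on the pyrazole-bearing core

The compounds below may be only part of what the source reports. "The series", "measured", "known", "first", "only" and "open" are said of these compounds alone.

Compound 1 `NS(=O)(=O)c1ccc2nc(-n3nc(C(F)(F)F)cc3-c3ccc(Br)cc3)sc2c1`: 45%
Compound 2 `NS(=O)(=O)c1ccc2nc(-n3nc(C(F)(F)F)cc3-c3ccc4ccccc4c3)sc2c1`: 30%

Of the compounds shown here, two sharing one core have been measured in a functional assay on the whole organism (strain Wistar albino) for inhibition, with Rattus norvegicus as the target, read by paw edema, with stated times of 30 min and 1 h, at a dose of 50 mg/kg by the oral route; a higher number here means more inhibition at the dose given (going by the name of the read-out), a lower number less inhibition. Compound 1 bears a 4-bromophenyl group and gives 45%. For the measured compounds named here, compound 2 carries naphthalen-2-yl in its place and gives 30%, which is the lower of the two numbers; the only measured step, a number 15 percentage points lower from compound 1 to compound 2 (beyond the scatter), lies beyond the scatter.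

Compound 3 `NS(=O)(=O)c1ccc2nc(-n3nc(C(F)(F)F)cc3-c3ccc(F)cc3)sc2c1` is not yet measured. It differs from compound 2 as follows: 4-fluorophenyl in place of naphthalen-2-yl on an aromatic carbon. Going by the values given here, the one measured step bears directly on this change, since it runs in the opposite sense, from a single six-membered aromatic ring of carbon only to naphthalen-2-yl, and lowered the read-out by a modest amount. Because the step of a number 15 percentage points lower from compound 1 to compound 2 (beyond the scatter) went down, a return to a single ring bearing a halogen is expected to bring the number back up toward compound 1, though fluorine in place of bromine adds an uncertainty of its own. The step of a number 10 percentage points higher from compound 2 to compound 3 (within the scatter) is therefore expected to be upward and modest. Compound 3 is estimated at 40%, within 25% to 55%.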

Compound 3, a percentage reported as inhibition, in the whole organism at one dose (the size of the read-out at that dose, not a potency): 54%
For compound 3 the middle estimate is 14 percentage points below the measured one, and the stated range covers the measured number.
By their numbers in this assay, from the lowest: compound 2; then compounds 1 and 3 (each within the scatter of the next).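

In this assay the step of a number 24 percentage points higher from compound 2 to compound 3 (beyond the scatter) shows that this position, on an aromatic carbon of the five-membered ring with two nitrogens, responds to the change from the two-ring naphthalen-2-yl group to the one-ring 4-fluorophenyl group. Taken with a number 15 percentage points lower from compound 1 to compound 2 (beyond the scatter) it means that both compounds with a single halogen-bearing ring, compound 1 and compound 3, stand clear of compound 2, so the lower number of compound 2 is no longer tied to bromine alone. The halogen itself is not resolved, as the step of a number 9 percentage points higher from compound 1 to compound 3 (within the scatter) leaves fluoro and bromo on that ring indistinguishable in this read-out. No other kind of measurement accompanies these numbers, so they stand without an explanation.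

From the compounds shown here alone, what remains open is whether a phenyl ring with no halogen, or one bearing an amine or a carboxylic acid, would stand with compound 1 and compound 3 or with compound 2. Going by these compounds, each number is also the size of the read-out at a single dose and not a potency, so whether the same picture holds at other doses stays unknown.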